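Oxan-2-yl in place of oxolan-3-yl: working notes

This account rests on a few compounds, and the source may have more. Where it says the series, first, only, none or still open, it means among the compounds named here.

Compound 1 `Cc1ccc(C(=O)Nc2cccc(C(F)(F)F)c2)cc1-c1ccc2c(-c3cnn(CC(C)O)c3)n[nH]c2c1`: 339 nM
Compound 2 `Cc1ccc(C(=O)Nc2cccc(C(F)(F)F)c2)cc1-c1ccc2c(-c3cnn(C4CCOC4)c3)n[nH]c2c1`: 304 nM

In a functional assay on KG-1 cells (Homo sapiens) for antiproliferative activity, read by CCK-8 assay, with a stated time of 72 h (a lower number here means a stronger inhibitor, a higher number a weaker inhibitor), compound 2 stands at 304 nM, and this value lies within the scatter of the value for compound 1. The two cannot be ranked.

Compound 3 `Cc1ccc(C(=O)Nc2cccc(C(F)(F)F)c2)cc1-c1ccc2c(-c3cnn(C4CCCCO4)c3)n[nH]c2c1` is not yet measured. It carries oxan-2-yl in place of oxolan-3-yl on an aromatic nitrogen.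

For the measured compounds named here, one measured step bears on this change: a 1.1-fold lower number from compound 1 to compound 2 (0.05 log units; within the scatter). That step exchanged 2-hydroxypropyl for oxolan-3-yl on an aromatic nitrogen and stayed within the scatter. Going by the values given here, it is a single step, and no measured compound carries a six-membered non-aromatic ring here, so the range stays wide.

No step beyond the scatter is expected in this assay, and no direction is favoured: the expected step is a 1.1-fold higher number from compound 2 to compound 3 (0.04 log units; within the scatter). The estimate for compound 3 is 330 nM, with an expected range of 140 nM to 750 nM.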

Compound 3, half-maximal inhibitory concentration: 121 nM
Compound 3: the middle estimate sits 2.7-fold (0.44 log units) above what was measured; measured number outside the range, below it.
By their numbers in this assay, from the lowest: compound 3; then compounds 2 and 1 (each within the scatter of the next).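

In this assay, the group on the aromatic nitrogen can now be seen to move the number beyond the scatter, which the earlier pair did not show: oxan-2-yl gives a 2.5-fold lower number from compound 2 to compound 3 (0.40 log units; beyond the scatter), and, against the open chain, a 2.8-fold lower number from compound 1 to compound 3 (0.45 log units; beyond the scatter). Both steps are modest, but oxan-2-yl separates from 2-hydroxypropyl and oxolan-3-yl, two groups that could not be ranked against each other. No measured evidence bears on the origin of this shift.

The change alters ring size and point of attachment together, so the compounds shown cannot tell which of the two matters, and oxan-4-yl or oxolan-2-yl would bear on that question. From the compounds shown here alone, it also remains open whether a ring with a basic amine, such as piperidin-4-yl, would follow oxan-2-yl.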